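Swapping a Furan for a Pyridine on a Shared Core

This account rests on a few compounds, and the source may have more. Where it says the series, first, only, none or still open, it means among the compounds named here.

Compound 2 `COc1ccc2[nH]c3c(c2c1)CCNC31CCN(Cc2ccco2)CC1` gives 16400 nM in an assay on FRT cells for positive allosteric modulation of Cystic fibrosis transmembrane conductance regulator variant N1303K (Homo sapiens), in the presence of a further agent that is not named here (a lower number here means that less compound is needed, a higher number that more compound is needed for the effect), the higher of the two measured numbers. Compound 1 `COc1ccc2[nH]c3c(c2c1)CCNC31CCN(Cc2cc(F)c(F)c(F)c2)CC1` gives 2600 nM, and the step of a 6.3-fold higher number from compound 1 to compound 2 (0.80 log units; beyond the scatter) shows that the group on this carbon matters. Compound 3 `COc1ccc2[nH]c3c(c2c1)CCNC31CCN(Cc2cccnc2)CC1` carries pyridin-3-yl in place of furan-2-yl on a saturated chain carbon bound to an amine nitrogen in a ring. Among the compounds with values here, no measured step covers a furan-to-pyridine exchange, so the direction is uncertain; the only step bearing on this position is the one between compound 1 and compound 2, whose size suggests that changes here can be modest but real. Compound 3 is therefore expected near 8000 nM, with a range from 2500 nM to 25000 nM, an estimated step of a 2.1-fold lower number from compound 2 to compound 3 (0.31 log units; beyond the scatter).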

Compound 3, half-maximal effective concentration: 17000 nM
Beside the measured number, compound 3's estimate is 2.1-fold (0.33 log units) below it; the range from low to high includes it.
By their numbers in this assay, from the lowest: compound 1; then compounds 2 and 3 (each within the scatter of the next).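

Exchanging the five-membered furan-2-yl for the six-membered pyridin-3-yl makes no readable difference on this carbon: a 1.0-fold higher number from compound 2 to compound 3 (0.02 log units; within the scatter). The 3,4,5-trifluorophenyl group now stands apart from two different rings rather than one, with a 6.5-fold higher number from compound 1 to compound 3 (0.82 log units; beyond the scatter). Nothing available here explains either result. The compounds shown leave open whether the fluorine atoms or the phenyl ring itself set compound 1 apart, which a plain unsubstituted phenyl group on this carbon could help separate.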